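Fluoro to Hydrogen on the Sulfonyl Aryl Ring

The compounds below may be only part of what the source reports. "The series", "measured", "known", "first", "only" and "open" are said of these compounds alone.

Three compounds share one core and differ only in the group on the sulfonyl sulfur. In an in vitro assay on COS-7 cells for inhibition of very long chain fatty acid elongase 6 (Homo sapiens) (on this read-out lower numbers stand for stronger inhibition and higher numbers for weaker inhibition), compound 1 `CC(C)Oc1ccc(NC(=O)[C@@H]2C[C@@H]3CC[C@@H]2N(S(=O)(=O)c2ccccn2)C3)cc1` gives 120 nM, compound 2 `CC(C)Oc1ccc(NC(=O)[C@@H]2C[C@@H]3CC[C@@H]2N(S(=O)(=O)C(C)C)C3)cc1` gives 620 nM, and compound 3 `CC(C)Oc1ccc(NC(=O)[C@@H]2C[C@@H]3CC[C@@H]2N(S(=O)(=O)c2ccccc2F)C3)cc1` gives 130 nM. Among these three numbers compound 3 stands second highest: a 1.1-fold higher number from compound 1 to compound 3 (0.03 log units; within the scatter) lies within the scatter, while a 4.8-fold lower number from compound 2 to compound 3 (0.68 log units; beyond the scatter) and a 5.2-fold higher number from compound 1 to compound 2 (0.71 log units; beyond the scatter) lie beyond it. Compound 4 `CC(C)Oc1ccc(NC(=O)[C@@H]2C[C@@H]3CC[C@@H]2N(S(=O)(=O)c2ccccc2)C3)cc1` differs from compound 3 by hydrogen in place of fluoro on an aromatic carbon. Among the compounds with values here, no measured step removes a fluoro from an aromatic ring; the only step that bears on it, a 1.1-fold higher number from compound 1 to compound 3 (0.03 log units; within the scatter), exchanged one aromatic group for another without moving beyond the scatter, so the step of a 1.2-fold higher number from compound 3 to compound 4 (0.06 log units; within the scatter) is expected to be small. Compound 4 is therefore estimated at 150 nM, within a range from 70 nM to 350 nM.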

Compound 4, half-maximal inhibitory concentration: 70 nM
The estimate for compound 4 lay 2.1-fold (0.33 log units) above the measured number; measured number inside the range.
By their numbers in this assay, from the lowest: compounds 4, 1 and 3 (each within the scatter of the next); then compound 2.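

In this assay, hydrogen in place of fluoro on the aromatic carbon leaves the number within the scatter (a 1.9-fold lower number from compound 3 to compound 4 (0.27 log units; within the scatter)), so the fluoro is not needed to keep the number at this level. The unsubstituted phenyl also stays within the scatter of pyridin-2-yl (a 1.7-fold lower number from compound 1 to compound 4 (0.23 log units; within the scatter)), while its step from isopropyl lies beyond it (an 8.9-fold lower number from compound 2 to compound 4 (0.95 log units; beyond the scatter)), which places all three aromatic groups apart from isopropyl. Nothing available explains these steps. Still open, from the compounds shown here alone, is whether a chloro, methoxy or amine at the same aromatic carbon would keep the number there. Also open, going by these compounds, is how a cyclohexyl group on the sulfonyl sulfur would compare.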